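The compounds below may be only part of what the source reports. "The series", "measured", "known", "first", "only" and "open" are said of these compounds alone.

In a physicochemical assay for lipophilicity, read by LC-MS (on this read-out lower numbers stand for lower lipophilicity and higher numbers for higher lipophilicity), the measured compounds read as follows

Compound 1 `FC(F)(F)c1nccc(N[C@H]2CC[C@@H](Nc3cnc4ccccc4c3)CC2)n1` gives 4.6
Compound 2 `FC(F)(F)c1nccc(N[C@H]2CC[C@@H](Nc3ccc4ncc(Cl)n4n3)CC2)n1` gives 4.3
Compound 3 `FC(F)(F)c1nccc(N[C@H]2CC[C@@H](Nc3ccc4nnc(Br)n4n3)CC2)n1` gives 2.9

Compound 3 stands lowest of the three, and compound 2 and compound 1 both lie above it by more than the scatter. Compound 4 `FC(F)(F)c1nccc(N[C@H]2CC[C@@H](Nc3ccc4nnc(C5CC5)n4n3)CC2)n1` differs from compound 3 in one place, with cyclopropyl in place of bromo on an aromatic carbon, between two ring nitrogen atoms (cyclopropyl in place of bromo on an aromatic carbon). Within the data shown here, no measured pair here differs in one place only, so the data offer no direct guide to this change. The expected step is a number 0.20 log units higher from compound 3 to compound 4 (within the scatter) and it is small and upward, perhaps no larger than the scatter. For compound 4 the estimated value in this assay is 3.1 with an expected range from 2.6 to 3.6 around it.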

Compound 4, distribution coefficient: 4.5
The estimate for compound 4 lay 1.40 log units below the measured number; measured number outside the range, above it.
By their numbers in this assay, from the lowest: compound 3; then compounds 2, 4 and 1 (each within the scatter of the next).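

In this assay, replacing bromo with cyclopropyl gives a number 1.60 log units higher from compound 3 to compound 4 (beyond the scatter) on this aromatic carbon, between two ring nitrogen atoms. Among these compounds, this is the first comparison in the set that isolates a single place, and it shows that one substituent change here can move the read-out well beyond the scatter. No evidence on hand accounts for the size of this step. Going by these compounds, it remains open how a methyl group, a dimethylamino group or a carboxylic acid would read in this assay at this carbon, and whether the same change would give a similar step on another core.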